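The compounds below may be only part of what the source reports. "The series", "measured", "known", "first", "only" and "open" are said of these compounds alone.

Measured in a functional assay on the whole organism for inhibition, with Mus musculus as the target; a lower number here means that less compound is needed, a higher number that more compound is needed for the effect:
Compound 1 `CCOC(=O)Nc1cccc2c1CN(C)CC2c1ccc(Cl)cc1`: 4.8 mg/kg
Compound 2 `CCCCNCC(=O)Nc1cccc2c1CN(C)CC2c1ccccc1`: 32 mg/kg
Compound 3 `CCCCNCC(=O)Nc1cccc2c1CN(C)CC2c1ccc(Cl)cc1`: 13.5 mg/kg

Compound 3 stands in the middle of these three numbers, with compound 2 higher and compound 1 lower. Compound 4 `CCCCNCC(=O)Nc1cccc2c1CN(C)CC2c1ccc(C)cc1` differs from compound 3 at one place: methyl in place of chloro on an aromatic carbon. The step that bears most directly on this change lies at that same place, a 2.4-fold lower number from compound 2 to compound 3 (0.37 log units; beyond the scatter), with chloro in place of hydrogen. The other step, a 2.8-fold higher number from compound 1 to compound 3 (0.45 log units; beyond the scatter), concerns a different part of the molecule and offers little guidance. Among the compounds with values here, no measured compound carries methyl, so only a small rise within the scatter is expected. The estimated change is a 1.3-fold higher number from compound 3 to compound 4 (0.12 log units; within the scatter). Compound 4 is expected at 18 mg/kg, within a range of 9 mg/kg to 36 mg/kg.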

Compound 4, dose for half-maximal effect: 34 mg/kg
Beside the measured number, compound 4's estimate is 1.9-fold (0.28 log units) below it, within the range that was stated.
By their numbers in this assay, from the lowest: compound 1; then compound 3; then compounds 2 and 4 (each within the scatter of the next).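

In this assay, this position does not respond to just any group in place of hydrogen: methyl gives a 1.1-fold higher number from compound 2 to compound 4 (0.03 log units; within the scatter), so the two compounds cannot be told apart. Replacing chloro with methyl gives a 2.5-fold higher number from compound 3 to compound 4 (0.40 log units; beyond the scatter), which shows that the earlier step with chloro does not extend to methyl, a group of the same heavy-atom count. The compounds shown leave open whether fluoro, bromo or methoxy at this place would match chloro or methyl. Nothing available explains why chloro and methyl differ here.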